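The source may report more compounds than this note shows. Statements on the series, on what has been measured and on what is new or still open speak of the compounds shown alone.

Compound 1 `CCCNC(=O)CC1CCc2cc(OC)c(OC)cc21` and compound 2 `COc1cc2c(cc1OC)C(CC(=O)NCc1ccccc1)CC2` share one core and differ only at the chain attached to the amide nitrogen. In a functional assay on the whole organism (strain Wistar) for inhibition, with Rattus norvegicus as the target, read by paw edema, with stated times of 60 min and 3 h, at a dose of 100 mg/kg by the oral route (a lower number here means less inhibition, a higher number more inhibition at the dose given (going by the name of the read-out)), compound 1 gives 29%, and in this assay compound 2 gives 14.5%. The step of a number 14.5 percentage points lower from compound 1 to compound 2 (beyond the scatter) is the only one measured, and it goes with phenyl in place of ethyl on a saturated chain carbon bound to an amide-type nitrogen. Compound 2 thus stands lowest of the two numbers, with compound 1 the nearer and higher value.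

Compound 3 `COc1cc2c(cc1OC)C(CC(=O)N1CCCC1)CC2` has not been measured. It differs from compound 2 by pyrrolidin-1-yl in place of benzylamino on a carbonyl carbon. Within the data shown here, the measured step bears on this only in part: it shows that adding a phenyl ring at that chain lowered inhibition, and compound 3 loses that ring again, but compound 3 also gives up the hydrogen-bond donor that both compound 1 and compound 2 carry, and no measured step speaks to that. An expected step of a number 7.5 percentage points higher from compound 2 to compound 3 (within the scatter) in this assay therefore seems reasonable, an increase that may not exceed the scatter. For compound 3 the estimated value in this assay is 22%, within a range from 8% to 38%.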

Compound 3, a percentage reported as inhibition, in the whole organism at one dose (the size of the read-out at that dose, not a potency): 26.1%
Estimate against measurement, compound 3: 4.1 percentage points below, and the stated range covers the measured number.
By their numbers in this assay, from the lowest: compound 2; then compounds 3 and 1 (each within the scatter of the next).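

In this assay, pyrrolidin-1-yl in place of benzylamino on a carbonyl carbon gives a number 11.6 percentage points higher from compound 2 to compound 3 (beyond the scatter), showing that the number at this position can be regained with the amide hydrogen gone. Pyrrolidin-1-yl in place of propylamino gives a number 2.9 percentage points lower from compound 1 to compound 3 (within the scatter), so at this position the two compounds cannot be told apart, even though only one of them keeps the amide hydrogen. The change from benzylamino removes the six-membered aromatic ring and the amide hydrogen together, so these compounds cannot assign the step to either one, and no separate measurement explains the result.

On these data alone, it remains open whether other groups on the carbonyl carbon, such as piperidin-1-yl, morpholin-4-yl or dimethylamino, would stay in the same range, and whether N-methylbenzylamino would separate the loss of the amide hydrogen from that of the aromatic ring. These numbers also come from a single oral dose, so they leave the potency of all three compounds open, along with how each would respond at other doses.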